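The source may hold more compounds than are shown below. What is called first, only, known or untested is meant among the compounds shown, and "the series" means these compounds.

Working notes on the series, read in an ADME assay on J774.A1 cells (Mus musculus) for cytotoxicity, read by MTT assay, with a stated time of 48 h; on this read-out higher numbers stand for lower toxicity in this test and lower numbers for higher toxicity in this test. Compound 1 `C/C(=C\c1ccccc1)C(=O)/C=C/c1ccccc1` gives 34500 nM, compound 2 `COc1ccc(/C=C(\C)C(=O)/C=C/c2ccccc2)cc1` gives 54000 nM, and compound 3 `COc1ccc(/C=C(\C)C(=O)/C=C/c2ccc([N+](=O)[O-])cc2)cc1` gives 30000 nM. Compound 2 lies within the scatter of both other compounds, so these three values set no order.

The next compound is compound 4 `C/C(=C\c1ccc([N+](=O)[O-])cc1)C(=O)/C=C/c1ccccc1`, which is still unmeasured. The change is nitro in place of methoxy on an aromatic carbon, para to a large group. Within the data shown here, no measured step makes this exact exchange, but two bear on it in part. Methoxy in place of hydrogen on an aromatic carbon gives a 1.6-fold higher number from compound 1 to compound 2 (0.19 log units; within the scatter). Nitro in place of hydrogen on an aromatic carbon gives a 1.8-fold lower number from compound 2 to compound 3 (0.26 log units; within the scatter), although compound 3 keeps the methoxy and carries its nitro at another place, so this step is only an indirect guide.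

Both steps are small, and both point to a modest move towards a lower number in this assay, with nothing expected beyond the scatter. The expected step is a 1.7-fold lower number from compound 2 to compound 4 (0.23 log units; within the scatter). The estimate for compound 4 is 32000 nM, with an expected range from 14000 nM to 70000 nM.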

Compound 4, half-maximal cytotoxic concentration: 47300 nM
Estimate against measurement, compound 4: 1.5-fold (0.17 log units) below; low and high end bracket the measured number.
By their numbers in this assay, from the lowest: compounds 3, 1, 4 and 2 (each within the scatter of the next).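

Nitro in place of methoxy on an aromatic carbon, para to a large group, gives a 1.1-fold lower number from compound 2 to compound 4 (0.06 log units; within the scatter), the first direct reading of this exchange in this assay. Nitro in place of hydrogen at the same place gives a 1.4-fold higher number from compound 1 to compound 4 (0.14 log units; within the scatter), so hydrogen, methoxy and nitro at this place now form a set of three with every printed step among them within the scatter, and none of the three can be ranked above another. The earlier nitro step, with the group at another place and methoxy kept, could only hint at this, and the two nitro steps together give no sign that the change depends on the core: the same change on two cores in this assay, a 1.8-fold lower number (0.26 log units; within the scatter) from compound 2 to compound 3 and a 1.4-fold higher number (0.14 log units; within the scatter) from compound 1 to compound 4, 2.5-fold (0.39 log units) apart, within the scatter of two such steps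

The compounds shown leave open whether this position has any bearing on the number in this assay, since no step at it lies beyond the scatter. An amine or a carboxylic acid at this place, or a longer chain in place of methoxy, would test whether a group of another kind moves the number further than the three groups seen so far.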